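Trimming the amine: from isopropyl to two methyl groups

The source may report more compounds than this note shows. Statements on the series, on what has been measured and on what is new or still open speak of the compounds shown alone.

This series shares one core carrying a diphenylamine-bearing ether and a benzylic amine. Compound 1 `COc1cc(Oc2cccc(Nc3ccccc3)c2)cc(OC)c1CNC1CC1` in a functional assay on HCT-116 cells (Homo sapiens) for inhibition, read by MTT assay, with a stated time of 72 h (on this read-out lower numbers stand for stronger inhibition and higher numbers for weaker inhibition), gives only a limit, > 20000 nM. Compound 2 `COc1cc(Oc2cccc(Nc3ccccc3)c2)cc(OC)c1CNC(C)C` in this assay likewise gives only a limit, > 20000 nM, so its position is known only as sitting at the limit of > 20000 nM in this assay, at which 2 of the 3 values shown sit. Compound 3 `COc1ccc([C@@H](C)NCc2c(OC)cc(Oc3cccc(Nc4ccccc4)c3)c(OC)c2OC)cc1` differs from compound 2 in several places at once; in this assay compound 3 gives 2440 nM. For the measured compounds named here, the single measured step, a step that the two limits leave unreadable from compound 1 to compound 2, is unreadable because both ends are limits, so it cannot show how changes at the amine nitrogen move potency.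

Compound 4 `COc1cc(Oc2cccc(Nc3ccccc3)c2)cc(OC)c1CN(C)C` carries the change (dimethylamino in place of isopropylamino on a saturated chain carbon bound to an aromatic carbon). Going by the values given here, no measured step bears on this change directly, and compound 2 itself is known only as a limit, so no direction or size beyond the scatter can be expected with confidence. Compound 4 is therefore estimated at 25000 nM, within a range from 6000 nM to 80000 nM. The expected step that the limit leaves unreadable from compound 2 to compound 4 reflects that estimate, and a further limit rather than a number is the likeliest outcome.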

Compound 4, half-maximal inhibitory concentration: 12900 nM
Estimate against measurement, compound 4: 1.9-fold (0.29 log units) above, within the range that was stated.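

In this assay compound 4 gives 12900 nM, a real number rather than a limit, which the other two simple amines on this shared core did not provide. Dimethylamino in place of isopropylamino gives an at least 1.5-fold lower number from compound 2 to compound 4 (0.19 log units; that floor lies within the scatter), and dimethylamino in place of cyclopropylamino gives an at least 1.5-fold lower number from compound 1 to compound 4 (0.19 log units; that floor lies within the scatter). These floors alone do not establish a gain at this position, and the true size of both steps stays unknown because each starts from a limit: the limit of > 20000 nM in this assay, at which 2 of the 4 values shown sit.

Going by these compounds, it remains open how a primary amine, a methylamino group or a ring amine such as morpholine would read at this place. Compound 3 differs from these compounds in several places, so its value cannot be tied to the group on the amine nitrogen alone.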